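The source may hold more compounds than are shown below. What is called first, only, known or untested is meant among the compounds shown, and "the series" means these compounds.

In a functional assay on ileum for inhibition of histamine H1 receptor (Cavia porcellus) (a higher number here means a weaker inhibitor, a lower number a stronger inhibitor), three compounds have been measured so far. Compound 1 `CCCN1CCCN(c2nc3ccccc3n2CCOCC)CC1` gives 8.4 nM, compound 3 `CCCCN1CCN(c2nc3ccccc3n2CCOCC)CC1` gives 15 nM, and compound 2 `CCSCCn1c(N2CCN(C)CC2)nc2ccccc21` gives 19 nM. Compound 2 stands highest of the three numbers: its gap to compound 3 lies within the usual scatter of repeated measurements, while its gap to compound 1 lies beyond it. Compound 4 `CCCC(C)n1c(N2CCN(C)CC2)nc2ccccc21` has not yet been measured. It differs from compound 2 in one place (1-methylbutyl in place of 2-(ethylsulfanyl)ethyl on an aromatic nitrogen). Within the data shown here, no measured pair shows this same change, so these numbers alone do not tell how large its effect will be. The step of a 1.3-fold higher number from compound 2 to compound 4 (0.12 log units; within the scatter) that the estimate means is expected to be small, not clearly beyond the scatter. For compound 4 the estimated value in this assay is 25 nM, with a range from 8 nM to 80 nM.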

Compound 4, half-maximal inhibitory concentration: 1400 nM
Compound 4: the middle estimate sits 56-fold (1.75 log units) below what was measured; measured number outside the range, above it.
By their numbers in this assay, from the lowest: compounds 1, 3 and 2 (each within the scatter of the next, the first and the last beyond it); then compound 4.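

In this assay the group on the aromatic nitrogen matters greatly: 1-methylbutyl in place of 2-(ethylsulfanyl)ethyl gives a 74-fold higher number from compound 2 to compound 4 (1.87 log units; beyond the scatter) and thus a much weaker inhibitor. Both groups have 5 heavy atoms and no ring, so matching size by that count does not make them interchangeable at this position. No measurement here bears on why the step is so large. The compounds shown leave open whether the step follows the lost sulfur or the methyl branch of the new group. A straight pentyl chain at this position would help separate the two.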